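A few compounds are considered here, and "the series" means these few. Any claim that something is new, unique, unknown or untested is made for them only; others in the source may bear on it.

Compound 1 `CCOc1cc(C(=O)Nc2nn[nH]n2)nc(-c2ccc(C)cc2)c1` gives 26% in a functional assay on the whole organism for inhibition, with Rattus norvegicus as the target, at a dose of 0.3 mg/kg by the oral route; on this read-out lower numbers stand for a weaker effect and higher numbers for a stronger effect at the one dose given.
Compound 2 `CCOc1cc(C(=O)Nc2nn[nH]n2)nc(-c2ccc(N)cc2)c1` gives 19% in this assay.
Compound 3 `Cc1ccc(-c2cccc(C(=O)Nc3nn[nH]n3)n2)cc1` gives 21% in this assay.

Compound 2 differs from compound 1 by one change, (amino in place of methyl on an aromatic carbon), and this change made a number 7 percentage points lower from compound 1 to compound 2 (within the scatter). Compound 3 differs from compound 1 in its core, (hydrogen in place of ethoxy on an aromatic carbon), and that change made a number 5 percentage points lower from compound 1 to compound 3 (within the scatter). Compound 4 `Nc1ccc(-c2cccc(C(=O)Nc3nn[nH]n3)n2)cc1` has not yet been measured in this assay. It differs from compound 3 by amino in place of methyl on an aromatic carbon. This is the same change that turns compound 1 into compound 2, made on the core of compound 3 instead of the core of compound 1; the surroundings of the place where the change is made read the same in both cases.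

Within the data shown here, the only earlier example of this change, a number 7 percentage points lower from compound 1 to compound 2 (within the scatter), stayed within the scatter, so for compound 4 a step of similar size is expected, namely a number 6 percentage points lower from compound 3 to compound 4 (within the scatter). Because compound 3 gives 21%, compound 4 is estimated at 15% in this assay, expected to fall between 4% and 26%.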

Compound 4, a percentage reported as inhibition, in the whole organism at one dose (the size of the read-out at that dose, not a potency): 11%
For compound 4 the middle estimate is 4 percentage points above the measured one; measured number inside the range.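

Going from 4-methylphenyl to 4-aminophenyl in this assay gives a number 10 percentage points lower from compound 3 to compound 4 (within the scatter), and this step reads much like the one on the other core: the same change on two cores in this assay, a number 7 percentage points lower (within the scatter) from compound 1 to compound 2 and a number 10 percentage points lower (within the scatter) from compound 3 to compound 4, 3 percentage points apart, within the scatter of two such steps. Putting hydrogen in place of ethoxy gives a number 8 percentage points lower from compound 2 to compound 4 (within the scatter), and this step also agrees with its earlier counterpart: the same change on two cores in this assay, a number 5 percentage points lower (within the scatter) from compound 1 to compound 3 and a number 8 percentage points lower (within the scatter) from compound 2 to compound 4, 3 percentage points apart, within the scatter of two such steps. Across these four compounds, each change therefore behaves alike on both cores, but every step lies within the scatter, so none is shown to be a real change in effect, and two pairs of small steps do not establish a rule for the wider series.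

The compounds shown carry only methyl or amino on the outer ring and only ethoxy or hydrogen on the core, so it remains open whether a carboxylic acid or a longer chain would carry across the cores in the same way. Each figure also comes from a single dose, which leaves open how these compounds compare at other doses.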